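The source may hold more compounds than are shown below. What is called first, only, known or untested is meant among the compounds shown, and "the series" means these compounds.

Compound 1 `O=C(O)c1cccc(-c2ccc(/C=C3\S/C(=N\c4ccc(Cl)cc4)N(c4ccc(Cl)cc4)C3=O)o2)c1` was tested in an ADME assay on Vero cells (Chlorocebus sabaeus) for cytotoxicity; on this read-out higher numbers stand for lower toxicity in this test and lower numbers for higher toxicity in this test. In this assay compound 1 gives only a limit, > 200000 nM, and no number. Two related compounds give the same picture. Compound 2 `O=C(O)c1cccc(-c2ccc(/C=C3\S/C(=N\c4ccc(F)cc4)N(c4ccc(F)cc4)C3=O)s2)c1` reaches only the limit > 200000 nM in this assay. Compound 3 `O=C(O)c1cccc(-c2ccc(/C=C3\S/C(=N\c4ccccc4)N(c4ccc(Cl)cc4)C3=O)s2)c1` likewise stops at the limit > 200000 nM in this assay. So compound 1 stands where every measured value stands, as all three sit at the limit of > 200000 nM in this assay, at which 3 of the 3 values shown sit, and no step between measured compounds can be worked out from them.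

Compound 4 `O=C(O)c1cccc(-c2ccc(/C=C3\S/C(=N\c4ccc(Cl)cc4)N(c4ncccc4F)C3=O)o2)c1` differs from compound 1 in one place: 3-fluoropyridin-2-yl in place of 4-chlorophenyl on an amide-type nitrogen in a ring. For the measured compounds named here, no measured step speaks to this change, and the three limits give no direction. The step from compound 1 to compound 4 in this assay is therefore expected to be none beyond the scatter, a number no higher from compound 1 to compound 4 (the limit leaves the size open). Compound 4 is estimated to give 200000 nM in this assay, with a range from 60000 nM to 400000 nM, most probably again as a limit rather than a number.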

Compound 4, half-maximal cytotoxic concentration: > 200000 nM
Compound 4 was reported as a limit; the forecaster's own chance of this, stated with the estimate: 80%; the middle value sits exactly at the limit.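

Compound 1 and compound 4 both give only a limit in this assay, so no step can be read between them: the limit of > 200000 nM in this assay, at which 4 of the 4 values shown sit.

The compounds shown leave open what number any of them would give, and whether 3-fluoropyridin-2-yl in place of 4-chlorophenyl changes that number at all.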